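Cytotoxicity limits and the step to compound 3

The compounds below may be only part of what the source reports. "The series", "measured", "known", "first", "only" and "open" are said of these compounds alone.

Measured compounds:
- compound 1 `CCCc1nn(C)c2c(Nc3ccc(C(=O)O)cc3)nc(-c3cc(OC)c(OC)c(OC)c3)nc12`: > 50000 nM (a limit)
- compound 2 `CCCc1nn(C)c2c(N3CCCC3)nc(-c3cc(OC)c(OC)c(OC)c3)nc12`: > 50000 nM (a limit)

In an ADME assay on RAW264.7 cells (Mus musculus) for cytotoxicity (a lower number here means a stronger inhibitor, a higher number a weaker inhibitor), compound 2 gives only a limit, > 50000 nM. Compound 1 gives no number either: the result shown for it is also a limit. The record so far is the limit of > 50000 nM in this assay, at which 2 of the 2 values shown sit.

Compound 3 `CCCc1nn(C)c2c(NC(C)C)nc(-c3cc(OC)c(OC)c(OC)c3)nc12` has isopropylamino in place of pyrrolidin-1-yl on an aromatic carbon.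

For the measured compounds named here, the one measured step, a step that the two limits leave unreadable from compound 1 to compound 2, has no readable size to carry over to this change. No definite shift in this assay is therefore expected, in either direction, and a further limit is the likeliest result. This expectation rests only on (the limit of > 50000 nM in this assay, at which 2 of the 2 values shown sit). The expected step is a number no higher from compound 2 to compound 3 (the limit leaves the size open). For compound 3 the estimated value is 50000 nM, with an expected range of 15000 nM to 100000 nM.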

Compound 3, half-maximal inhibitory concentration: > 50000 nM
Compound 3 ended at the assay's limit; the forecaster's own chance of this, stated with the estimate: 85%; the middle value sits exactly at the limit.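

In this assay compound 3 gives > 50000 nM as a limit, not a number. For the compounds shown here, no step among compound 1, compound 2 and compound 3 can be read, as all three results are limits. The compounds shown leave open whether any of these substituents on the aromatic carbon shifts the read-out in this assay at all.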